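Ester side-chain variation on the quinolinone series: cytotoxicity notes

A few compounds are considered here, and "the series" means these few. Any claim that something is new, unique, unknown or untested is made for them only; others in the source may bear on it.

Measured so far:
compound 1, `O=c1c(CCO)c(-c2ccccc2Cl)c2cc(Cl)ccc2n1-c1ccccc1`, 26000 nM in an ADME assay on HepG2 2.2.15 cells (Homo sapiens) for cytotoxicity; on this read-out lower numbers stand for higher toxicity in this test and higher numbers for lower toxicity in this test
compound 2, `CC(=O)OCC(=O)OCCc1c(-c2ccccc2Cl)c2cc(Cl)ccc2[nH]c1=O`, 100000 nM in this assay

Compound 2 holds the higher of the two numbers in this assay; its gap to compound 1 lies beyond the scatter, so compound 2 reads as the less toxic of the pair. Compound 3, `O=C(COc1ccccc1)OCCc1c(-c2ccccc2Cl)c2cc(Cl)ccc2[nH]c1=O`, differs from compound 2 by phenyl in place of acetyl on an oxygen on a saturated carbon. Among the compounds with values here, no step between measured compounds speaks to this change, so only a small shift, if any, is expected: the step of a 1.4-fold lower number from compound 2 to compound 3 (0.15 log units; within the scatter) is estimated to stay within the scatter, leaning toward a lower number. Compound 3 is expected to give 70000 nM in this assay, within 25000 nM to 150000 nM.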

Compound 3, half-maximal cytotoxic concentration: 81000 nM
Estimate against measurement, compound 3: 1.2-fold (0.06 log units) below; low and high end bracket the measured number.
By their numbers in this assay, from the lowest: compound 1; then compounds 3 and 2 (each within the scatter of the next).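

In this assay, phenyl in place of acetyl on an oxygen on a saturated carbon gives a 1.2-fold lower number from compound 2 to compound 3 (0.09 log units; within the scatter). Within the data shown here, a six-membered aromatic ring of carbon only is therefore accepted at this place with no shift beyond the scatter, which the earlier compounds, differing in more than one place, could not show. Open remain how an amine or a carboxylic acid in place of phenyl would read in this assay, and whether a longer chain at this oxygen would do the same. No measurement at hand accounts for the result.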